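Sulfonamide aryl variation in a pyrazole series

The source may report more compounds than this note shows. Statements on the series, on what has been measured and on what is new or still open speak of the compounds shown alone.

Measured compounds:
Compound 1 `CC(C)Cc1cc(CNS(=O)(=O)c2cccc(Cl)c2)nn1-c1ccccc1` gives 40.8% in an assay on isolated protein for binding affinity to 5-hydroxytryptamine receptor 6 (Homo sapiens), tested at 10 uM; on this read-out higher numbers stand for more inhibition at the one concentration tested (going by the name of the read-out) and lower numbers for less inhibition.
Compound 2 `CC(C)Cc1cc(CNS(=O)(=O)c2cccc3ccccc23)nn1-c1ccccc1` gives 77.7% in this assay.
Compound 3 `CC(C)Cc1cc(CNS(=O)(=O)c2ccccc2)nn1-c1ccccc1` gives 11.3% in this assay.

Compound 1 stands second highest of the three numbers. The nearest is compound 3, a step of a number 29.5 percentage points lower from compound 1 to compound 3 (beyond the scatter); the furthest is compound 2, a step of a number 36.9 percentage points higher from compound 1 to compound 2 (beyond the scatter). The step of a number 66.4 percentage points lower from compound 2 to compound 3 (beyond the scatter) shows the two aryl changes pulling the same way, so more carbon on the sulfonyl aryl has gone with more inhibition in every pair so far.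

Compound 4 `Cc1c(Cl)cccc1S(=O)(=O)NCc1cc(CC(C)C)n(-c2ccccc2)n1` differs from compound 1 by methyl in place of hydrogen on an aromatic carbon. Among the measured compounds shown here, no measured step is a methyl addition, so the bearing steps are indirect. The 1>3 step removes one substituent and drops modestly; the 1>2 step enlarges the aryl and rises largely. A single added methyl is a smaller change than either, so a small rise, possibly within the scatter, is expected: a number 7.2 percentage points higher from compound 1 to compound 4 (within the scatter).

Compound 4 is expected to give about 48% in this assay, with a range from 26% to 70%.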

Compound 4, a percentage reported as inhibition, at one concentration (the size of the read-out at that concentration, not a potency): 72.3%
For compound 4 the middle estimate is 24.3 percentage points below the measured one, outside the stated range (above it).
By their numbers in this assay, from the lowest: compound 3; then compound 1; then compounds 4 and 2 (each within the scatter of the next).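

Placed ortho to a chloro group, one methyl gives a number 31.5 percentage points higher from compound 1 to compound 4 (beyond the scatter) in this assay, so this carbon of the sulfonyl aryl ring responds strongly to a single added carbon. The 3-chloro-2-methylphenyl group stands a number 61 percentage points higher from compound 3 to compound 4 (beyond the scatter) and a number 5.4 percentage points lower from compound 2 to compound 4 (within the scatter), so in this small set a second fused ring as in naphthalen-1-yl is not required for inhibition at this level. Nothing available explains why this methyl has so large an effect.

Still open, going by these compounds, is whether the methyl gives the same rise without the chloro group, and whether an ethyl, a methoxy or a fluoro group in its place would match it. These single-concentration percentages also leave open how compound 4 and compound 2 compare in potency.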